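Replacing pyridin-2-yl in compound 3 with 4-nitrophenyl

This account rests on a few compounds, and the source may have more. Where it says the series, first, only, none or still open, it means among the compounds named here.

In a functional assay on HeLa cells (Homo sapiens) for inhibition, read by MTT assay, with a stated time of 48 h (a lower number here means a stronger inhibitor, a higher number a weaker inhibitor), compound 1 `CCOC(=O)C1=C(N/C=N/c2cccnc2Cl)Nc2[nH]nc(C)c2C1c1ccc(N(C)C)cc1` gives 4630 nM, compound 2 `CCOC(=O)C1=C(NN=C(C(C)=O)C(C)=O)Nc2[nH]nc(C)c2C1c1ccc(N(C)C)cc1` gives 17000 nM and compound 3 `CCOC(=O)C1=C(N/C=N/c2ccccn2)Nc2[nH]nc(C)c2C1c1ccc(N(C)C)cc1` gives 29200 nM. Compound 3 therefore sits level with compound 2 and clearly weaker than compound 1. a 1.7-fold higher number from compound 2 to compound 3 (0.23 log units; within the scatter) stays within the scatter, so those two are not separated. a 6.3-fold higher number from compound 1 to compound 3 (0.80 log units; beyond the scatter) lies beyond it, as does a 3.7-fold higher number from compound 1 to compound 2 (0.56 log units; beyond the scatter).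

The next change leads to compound 4 `CCOC(=O)C1=C(N/C=N/c2ccc([N+](=O)[O-])cc2)Nc2[nH]nc(C)c2C1c1ccc(N(C)C)cc1`: 4-nitrophenyl in place of pyridin-2-yl on a double-bonded nitrogen. Among the compounds with values here, only one measured step swaps one aromatic group for another at this same place: a 6.3-fold higher number from compound 1 to compound 3 (0.80 log units; beyond the scatter), with 2-chloropyridin-3-yl on compound 1. That step shows that the number can move with the group here, and by a modest amount. Within the data shown here, no measured compound carries 4-nitrophenyl or any carbon-only aromatic ring at this place, so the direction rests on thin evidence. Among the measured compounds shown here, compound 3 has the pyridin-2-yl group, and the one other aromatic group measured here, on compound 1, gives a lower number, so a modest move towards a lower number is expected. The expected step is a 2.2-fold lower number from compound 3 to compound 4 (0.35 log units; beyond the scatter), smaller than the one measured at this place. For compound 4 the estimated value is 13000 nM, with an expected range of 4000 nM to 40000 nM.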

Compound 4, half-maximal inhibitory concentration: 57800 nM
For compound 4 the middle estimate is 4.4-fold (0.65 log units) below the measured one, outside the stated range (above it).
By their numbers in this assay, from the lowest: compound 1; then compounds 2, 3 and 4 (each within the scatter of the next, the first and the last beyond it).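

In this assay, 4-nitrophenyl, the first carbon-only aromatic ring on this double-bonded nitrogen, is not separated from pyridin-2-yl: a 2.0-fold higher number from compound 3 to compound 4 (0.30 log units; within the scatter). Within the data shown here, the lower number on compound 1 therefore does not extend to this aromatic replacement, and 2-chloropyridin-3-yl stands apart from 4-nitrophenyl by a 12-fold higher number from compound 1 to compound 4 (1.10 log units; beyond the scatter), the largest step seen at this place so far. Compound 2, with its ring-free group on the amine nitrogen, is now resolved from an aromatic group other than 2-chloropyridin-3-yl, through a 3.4-fold higher number from compound 2 to compound 4 (0.53 log units; beyond the scatter), although compound 3 remains within the scatter of both compound 2 and compound 4.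

The compounds shown leave open whether the chlorine or the ring nitrogen accounts for the standing of compound 1, a question that unsubstituted pyridin-3-yl, 2-chlorophenyl or 4-aminophenyl at this place would address. No measurement shown here bears on what lies behind these differences in the numbers.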